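Trimethoxyphenyl chalcones with a substituted imidazolone ring

This account rests on a few compounds, and the source may have more. Where it says the series, first, only, none or still open, it means among the compounds named here.

Measured so far:
Compound 1 `COc1cc(/C=C/C(=O)c2cccc(-n3cc(-c4ccccc4)[nH]c3=O)c2)cc(OC)c1OC` gives 1510 nM in a functional assay on UO-31 cells (Homo sapiens) for inhibition; a higher number here means a weaker inhibitor of growth, a lower number a stronger inhibitor of growth.
Compound 2 `COc1ccc(-c2cn(-c3cccc(C(=O)/C=C/c4cc(OC)c(OC)c(OC)c4)c3)c(=O)[nH]2)cc1` gives 1910 nM in this assay.

Compound 2 holds the highest of the two numbers; its nearest neighbour is compound 1, and the step between them, a 1.3-fold higher number from compound 1 to compound 2 (0.10 log units; within the scatter), stays within the scatter, so the two cannot be ordered.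

Compound 3 `COc1cc(/C=C/C(=O)c2cccc(-n3cc(-c4cc(OC)c(OC)c(OC)c4)[nH]c3=O)c2)cc(OC)c1OC` carries the change (3,4,5-trimethoxyphenyl in place of 4-methoxyphenyl on an aromatic carbon). Among the compounds with values here, the only measured step that bears on this change is a 1.3-fold higher number from compound 1 to compound 2 (0.10 log units; within the scatter), which also added a methoxy to the same phenyl ring and gave no movement beyond the scatter. The new change adds two further methoxy groups to that ring; with a single, flat precedent there is no ground for expecting a large step in either direction in this assay, though the precedent leans slightly toward a higher number.

For compound 3 the expected value in this assay is 2300 nM, with a range from 1000 nM to 5500 nM. This estimate means a step of a 1.2-fold higher number from compound 2 to compound 3 (0.08 log units; within the scatter), expected to lie within the scatter.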

Compound 3, concentration for 50% growth inhibition: 960 nM
The estimate for compound 3 lay 2.4-fold (0.38 log units) above the measured number; measured number below the stated range.
By their numbers in this assay, from the lowest: compounds 3, 1 and 2 (each within the scatter of the next).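

In this assay the 3,4,5-trimethoxyphenyl group in place of 4-methoxyphenyl gives a 2.0-fold lower number from compound 2 to compound 3 (0.30 log units; within the scatter) and, in place of phenyl, gives a 1.6-fold lower number from compound 1 to compound 3 (0.20 log units; within the scatter), so neither step can be read as a real difference. The earlier pair covered only a single added methoxy on this ring, whereas compound 3 shows that the flat picture at this aromatic carbon of the five-membered ring extends to the 3,4,5-trimethoxyphenyl group, with compounds 1, 2 and 3 remaining unordered in this assay. No measurement is available that would explain these results or separate the three aryl groups beyond the scatter.

The compounds shown leave open whether this position stays equally flat when the phenyl ring carries something other than methoxy, such as a dimethylamino group or a carboxylic acid. They also leave open whether the aryl ring is needed at all, since a methyl group or a hydrogen at the same carbon would test that directly, and all three compounds here bear an aryl group at this place.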